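The compounds below may be only part of what the source reports. "The series", "measured", "known", "first", "only" and "open" are said of these compounds alone.

Measured compounds in a functional assay on SR cells (Homo sapiens) for inhibition, read by sulforhodamine B assay, with a stated time of 48 h; a lower number here means a stronger inhibitor of growth, a higher number a weaker inhibitor of growth:

compound 1 `N#C/C(=C\N1CCN(C(=O)c2ccco2)C1=S)C(=O)Nc1ccc(Cl)cc1`: 1600 nM
compound 2 `N#C/C(=C\N1CCN(C(=O)c2ccco2)C1=S)C(N)=O`: 3000 nM

Of the two numbers available, compound 2 carries the higher one; its nearest neighbour is compound 1, and the two lie within the scatter of each other, so no order between them can be stated. The pair gives the step of a 1.9-fold higher number from compound 1 to compound 2 (0.27 log units; within the scatter), which records that removing the aryl group from the amide-type nitrogen, leaving a primary amide, did not move the reading beyond the scatter.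

Compound 3 `N#C/C(=C\N1CCN(C(=O)c2ccco2)C1=S)C(=O)c1ccccc1` is not yet measured in this assay. It differs from compound 2 by phenyl in place of amino on a carbonyl carbon. Among the compounds with values here, this change sits on the carbonyl carbon itself rather than on the nitrogen, and no measured pair alters that position, so the only bearing evidence is indirect: the one measured step, the change between compound 1 and compound 2, was within the scatter. On that basis no step beyond the scatter is expected in this assay for the move to compound 3. Compound 3 is therefore estimated at 2200 nM, with a range from 700 nM to 7000 nM, corresponding to an expected step of a 1.4-fold lower number from compound 2 to compound 3 (0.13 log units; within the scatter).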

Compound 3, concentration for 50% growth inhibition: 2800 nM
The estimate for compound 3 lay 1.3-fold (0.10 log units) below the measured number, within the range that was stated.
By their numbers in this assay, from the lowest: compounds 1, 3 and 2 (each within the scatter of the next).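

In this assay, the carbonyl carbon now carries a measured change: carbamoyl to benzoyl gives a 1.1-fold lower number from compound 2 to compound 3 (0.03 log units; within the scatter) and so does not separate the two compounds, even though the amino group with its hydrogen-bond donor gives way to a six-membered aromatic ring of carbon only. Phenyl in place of (4-chlorophenyl)amino on the same carbon gives a 1.8-fold higher number from compound 1 to compound 3 (0.24 log units; within the scatter) and likewise stays inside the scatter, so in these three compounds a nitrogen on this carbonyl carbon is not needed for a reading at this level, and amino, (4-chlorophenyl)amino and phenyl cannot be put in any order. Nothing measured here accounts for the readings staying so close together.

Still open, going by these compounds, is whether this position tolerates every kind of group or only those seen so far, for instance a carboxylic acid, a tertiary amine on a longer chain or a simple methyl in place of the phenyl. The shared core is identical in all three compounds, so these numbers say nothing about how much of the reading depends on it.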